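The source may report more compounds than this note shows. Statements on the series, on what has been measured and on what is new or still open speak of the compounds shown alone.

Working notes on the series. Compound 1 (`C[C@]1(CN2CCc3nc(C4CCCCC4)ccc3C2)Cn2cc([N+](=O)[O-])nc2O1`) in an ADME assay on Vero cells (Chlorocebus sabaeus) for cytotoxicity, read by MTT assay, with a stated time of 72 h (a lower number here means that less compound is tolerated, a higher number that more compound is tolerated), is recorded as "not determined" (no result reported). Among the measured compounds shown here, compound 2 (`C[C@]1(CN2CCc3nc(-c4ccc(F)cc4F)ccc3C2)Cn2cc([N+](=O)[O-])nc2O1`) holds the only number: in this assay compound 2 gives 12.5 ug/mL, so nothing yet stands above or below it. Compound 3 (`C[C@]1(CN2CCc3nc(-c4cc(F)cc(Cl)c4)ccc3C2)Cn2cc([N+](=O)[O-])nc2O1`) differs in one place: 3-chloro-5-fluorophenyl in place of 2,4-difluorophenyl on an aromatic carbon. For the measured compounds named here, no step between measured compounds exists to calibrate this change, so the expectation is a step of no change at the digits printed from compound 2 to compound 3 (within the scatter), within the usual scatter, with no direction claimed. Compound 3 is therefore expected to give 12.5 ug/mL, with a range from 6 ug/mL to 25 ug/mL.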

Compound 3, half-maximal cytotoxic concentration: > 32 ug/mL
Compound 3: a limit, no number; the forecaster's own chance of this, stated with the estimate: 15%; middle value at least 2.5-fold (0.40 log units) away from the limit.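

In this assay, the substituents on the phenyl group at this position, on an aromatic carbon next to the ring nitrogen, can shift the result: 3-chloro-5-fluorophenyl in place of 2,4-difluorophenyl gives an at least 2.5-fold higher number from compound 2 to compound 3 (0.40 log units; beyond the scatter). The full size of this step cannot be read because compound 3 gives a limit of the assay, not a number: the limit of > 32 ug/mL in this assay, at which 1 of the 3 values shown sits.

A single pair cannot show whether the chlorine or the altered fluorine pattern carries the step. Going by these compounds, whether an amine or a carboxylic acid on this phenyl group would give a similar result also remains open.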